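The source may report more compounds than this note shows. Statements on the series, on what has been measured and on what is new or still open speak of the compounds shown alone.

Series on the shared core of compound 1 `COc1cccc(C(=O)Nc2cc(-c3ccccc3)nn2-c2ccccc2)c1`, which in an assay on HEK293 cells for displacement of a labelled ligand from metabotropic glutamate receptor 5 (Rattus norvegicus) (a lower number here means a stronger inhibitor, a higher number a weaker inhibitor), gives 1290 nM. Compound 2 `COc1cc(OC)cc(C(=O)Nc2cc(-c3ccccc3)nn2-c2ccccc2)c1` reaches only the limit of this assay, > 10000 nM. Compound 3 `O=C(Nc1cc(-c2ccccc2)nn1-c1ccccc1)c1ccncc1`, with pyridin-4-yl on the carbonyl carbon, likewise reaches only the limit, > 10000 nM. The steps of an at least 7.7-fold higher number from compound 1 to compound 2 (0.88 log units; beyond the scatter) and an at least 7.7-fold higher number from compound 1 to compound 3 (0.88 log units; beyond the scatter) are both beyond the scatter, whereas the step that the two limits leave unreadable from compound 2 to compound 3 cannot be read because of the limit of > 10000 nM in this assay, at which 2 of the 3 values shown sit. Compound 3 therefore stands at the weak end of the numbers shown, without a number of its own.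

Compound 4 `O=C(Nc1cc(-c2ccccc2)nn1-c1ccccc1)C1CCCCC1` differs from compound 3 in that (cyclohexyl in place of pyridin-4-yl on a carbonyl carbon). Among the compounds with values here, no measured step exchanges an aromatic group on the carbonyl carbon for a saturated ring, so none bears on this change directly; the only comparison within reach, an at least 7.7-fold higher number from compound 1 to compound 3 (0.88 log units; beyond the scatter), runs toward a weaker inhibitor. In this assay compound 4 is expected to remain near the limit, so an at least 1.1-fold lower number from compound 3 to compound 4 (0.04 log units; that floor lies within the scatter) is estimated as no change readable beyond the scatter. The estimate for compound 4 is 9000 nM, with a range from 2000 nM to 40000 nM.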

Compound 4, inhibition constant: 10100 nM
Compound 4: the middle estimate sits 1.1-fold (0.05 log units) below what was measured; measured number inside the range.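

Within the data shown here, the step of a 7.8-fold higher number from compound 1 to compound 4 (0.89 log units; beyond the scatter) puts a size on leaving 3-methoxyphenyl at this carbonyl carbon, where the earlier steps gave only a floor. Both a non-aromatic ring of carbon only, in compound 4, and pyridin-4-yl, in compound 3, fall away from compound 1, which remains the strongest of the four compounds shown. The steps from compound 2 and from compound 3 to compound 4 cannot be read because of this limit: the limit of > 10000 nM in this assay, at which 2 of the 4 values shown sit.

On these data alone, whether compound 4 truly differs from compound 2 or compound 3 stays open. Also open, as far as these compounds go, is how a chlorine on the phenyl ring in place of methoxy, a benzyl group or an open alkyl chain on the carbonyl carbon would compare with the 3-methoxyphenyl of compound 1.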